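The source may report more compounds than this note shows. Statements on the series, on what has been measured and on what is new or still open speak of the compounds shown alone.

Measured compounds:
compound 1 `CCCCC[Se]c1nc(NCc2ccccc2)c2ccccc2n1`: in a functional assay on MCF7 cells (Homo sapiens) for cytotoxicity, read by MTT assay, with a stated time of 72 h (on this read-out higher numbers stand for weaker inhibition of growth and lower numbers for stronger inhibition of growth), compound 1 gives 50 nM
compound 2 `[SeH]c1nc(NCc2ccccc2)c2ccccc2n1`: in this assay compound 2 gives > 100000 nM, which is a limit of the assay and not a number
compound 3 `Nc1nc([SeH])nc2ccccc12`: in this assay compound 3 gives 150 nM

Compound 4 `CCCCC[Se]c1nc(N)c2ccccc2n1` is not yet measured in this assay.

The change from compound 2 to compound 1 is pentyl in place of hydrogen on a selenium and it gave an at least 2000-fold lower number from compound 2 to compound 1 (3.30 log units; beyond the scatter); the size of that step rests on (the limit of > 100000 nM in this assay, at which 1 of the 3 values shown sits), so only its lower bound is known. The change from compound 3 to compound 4 is pentyl in place of hydrogen on a selenium, the same kind of change at the same kind of place. The difference between the core of compound 2 and the core of compound 3 is not broken down here. Compound 3 stands higher than compound 1, the gap between them being beyond the scatter.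

Among the compounds with values here, compound 3 already sits at a low number, so the step to compound 4 is expected to be far smaller than the one from compound 2 to compound 1: the estimate is a 3.0-fold lower number from compound 3 to compound 4 (0.48 log units; beyond the scatter), resting on compound 3 at 150 nM and on compound 1 at 50 nM as the nearest pentyl-bearing measured compound. Compound 4 is therefore expected at about 50 nM, within 10 nM to 250 nM.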

Compound 4, concentration for 50% growth inhibition: 28600 nM
The estimate for compound 4 lay 570-fold (2.76 log units) below the measured number, and the stated range ends below it.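

In this assay, pentyl in place of hydrogen on a selenium does not carry over from one core to the other, and the two steps run in opposite directions: the same change on two cores in this assay, an at least 2000-fold lower number (3.30 log units; beyond the scatter) from compound 2 to compound 1 and a 190-fold higher number (2.28 log units; beyond the scatter) from compound 3 to compound 4, at least 380000-fold (5.58 log units) apart, beyond the scatter of two such steps

Compound 2 gives > 100000 nM, which is a limit of the assay and not a number, so only a lower bound is known for the step on its core: the limit of > 100000 nM in this assay, at which 1 of the 4 values shown sits.

On the core of compound 3, the same change gives a 190-fold higher number from compound 3 to compound 4 (2.28 log units; beyond the scatter), while hydrogen in place of benzyl on a nitrogen on an aromatic ring gives a 570-fold higher number from compound 1 to compound 4 (2.76 log units; beyond the scatter), so the effect of pentyl depends on the core in these two pairs, but two pairs do not show why, nor what a third core would do.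

Open, as far as these compounds go, is whether the reversal is specific to pentyl, or whether a methyl, a longer chain such as octyl, or a chain ending in an amine or a carboxylic acid on the selenium would split the two cores in the same way. Also open, from the compounds shown here alone, is whether benzyl itself matters or whether a methyl or a phenethyl on that nitrogen would serve as well.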